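Carbamate for Amide on the Pyrazole: Lipophilicity Outlook

A few compounds are considered here, and "the series" means these few. Any claim that something is new, unique, unknown or untested is made for them only; others in the source may bear on it.

In a physicochemical assay for lipophilicity, at pH 7.4 (a higher number here means a more lipophilic compound, a lower number a more polar compound), the measured compounds stand as follows:
Compound 1 `Cc1cc(C(=O)NCc2cccnc2)nn1Cc1cc(Cl)ccc1OCc1ccccc1`: > 3.7
Compound 2 `Cc1cc(C(=O)NN2CCCCC2)nn1Cc1cc(Cl)ccc1OCC(C)C`: 3.3
Compound 3 `Cc1cc(C(=O)NN2CCOCC2)nn1Cc1cc(Cl)ccc1OCC(C)C`: 3.1.

For compound 1 the reading of > 3.7 is a limit of this assay and not a number (the limit of > 3.7 in this assay, at which 1 of the 3 values shown sits). Compound 4 `Cc1cc(NC(=O)OCc2ccccn2)nn1Cc1cc(Cl)ccc1OCc1ccccc1` differs from compound 1 by (((pyridin-2-yl)methoxy)carbonyl)amino in place of ((pyridin-3-yl)methyl)carbamoyl on an aromatic carbon. Going by the values given here, the only measured step, a number 0.20 log units lower from compound 2 to compound 3 (within the scatter), concerns a group on an amide-type nitrogen elsewhere on the shared core and does not touch the place changed here, so it gives little guidance. Since compound 1 sits at the limit, compound 4 is expected to remain close to it, with an estimated step that the limit leaves unreadable from compound 1 to compound 4. The estimate for compound 4 is 3.9, between 3.4 and 4.4.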

Compound 4, distribution coefficient: 3.1
Beside the measured number, compound 4's estimate is 0.80 log units above it; measured number below the stated range.
By their numbers in this assay, from the lowest: compounds 3, 4 and 2 (each within the scatter of the next). At a limit, above all of these: compound 1.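

In this assay, (((pyridin-2-yl)methoxy)carbonyl)amino in place of ((pyridin-3-yl)methyl)carbamoyl on this aromatic carbon gives the first step read at this position, a number at least 0.60 log units lower from compound 1 to compound 4 (beyond the scatter). The reading for compound 1 is a limit, so the step has only a smallest size and its full size cannot be read: the limit of > 3.7 in this assay, at which 1 of the 4 values shown sits.

The compounds shown do not separate the change of linking atoms from the change of pyridin-3-yl to pyridin-2-yl. Going by these compounds, how an amine or a carboxylic acid on this same carbon would read in this assay also stays open.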